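A Chloro Group Added to an Aromatic Ring

The source may hold more compounds than are shown below. What is called first, only, known or untested is meant among the compounds shown, and "the series" means these compounds.

Of the compounds shown here, two have been measured so far in a functional assay on WiDr cells (Homo sapiens) for inhibition, read by sulforhodamine B assay, with a stated time of 48 h; a higher number here means a weaker inhibitor of growth, a lower number a stronger inhibitor of growth. Compound 1, with the structure `O=C(/C(=C/c1ccc(Cl)cc1Cl)CCl)c1ccccc1`, gives 13000 nM. Compound 2, with the structure `C=C(C/C(=C\c1ccccc1)C(=O)c1ccccc1)C(=O)c1ccccc1`, gives 18000 nM. Of these two numbers compound 2 has the higher one, but the gap to compound 1 lies within the usual scatter of repeated measurements, so the two compounds cannot be told apart on these data.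

Compound 3, with the structure `C=C(C/C(=C\c1ccc(Cl)cc1)C(=O)c1ccccc1)C(=O)c1ccccc1`, has not yet been measured. It differs from compound 2 in one place: chloro in place of hydrogen on an aromatic carbon, so that a phenyl becomes a 4-chlorophenyl. Among the measured compounds shown here, no pair of measured compounds shows the effect of this particular change on its own. Compound 1 also carries chlorine on an aromatic ring and gave 13000 nM, but it differs from compound 2 in other places as well, so it offers only a loose hint.

The change is therefore expected to give a step of a 1.3-fold lower number from compound 2 to compound 3 (0.11 log units; within the scatter), which would stay within the scatter, with no clear direction. Compound 3 is estimated to give about 14000 nM, with a range from 6000 nM to 35000 nM.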

Compound 3, concentration for 50% growth inhibition: 20000 nM
For compound 3 the middle estimate is 1.4-fold (0.15 log units) below the measured one; the range from low to high includes it.
By their numbers in this assay, from the lowest: compounds 1, 2 and 3 (each within the scatter of the next).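

Among the compounds shown here, compound 3 gives the first direct reading of chloro in place of hydrogen on an aromatic carbon: in this assay, the change from phenyl to 4-chlorophenyl gives a 1.1-fold higher number from compound 2 to compound 3 (0.05 log units; within the scatter) and nothing more. This step lies within the scatter, so at this place on the six-membered aromatic ring, para to a large group, adding one chlorine atom has no effect that these data can detect, and compound 2 and compound 3 cannot be told apart. No separate measurement is available that could help interpret this result.

From the compounds shown here alone, a single substitution at a single position shows only that chloro and hydrogen cannot be separated here, so it remains open whether a different group on this ring, such as an amine, a carboxylic acid or a longer chain, would give a step beyond the scatter. Going by these compounds, it is also open whether chloro would give a similarly small step at another place on this ring, or on one of the other aromatic rings of the shared core.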